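Butoxy in place of diethylamino: compound 2 to compound 4

The source may hold more compounds than are shown below. What is called first, only, known or untested is meant among the compounds shown, and "the series" means these compounds.

In a functional assay on SW620/5-FU cells (Homo sapiens) for cytotoxicity, read by MTT assay, with a stated time of 48 h, in the presence of a further agent that is not named here (a higher number here means that more compound is needed for the effect, a lower number that less compound is needed), compound 1 (`CCCc1cc(NNC(=O)Nc2cc(Cl)nc(Cl)c2)nc2c1c(C)nn2C`) gives 40800 nM and compound 3 (`CC(C)c1cc(NNC(=O)Nc2cc(Cl)nc(Cl)c2)nc2c1cnn2C`) gives 50100 nM as measured values. Compound 2 (`CCN(CC)c1cc(NC(=O)NNc2cc(-c3ccc(F)cc3)c3cnn(C)c3n2)cc(Cl)n1`) gives 37000 nM in the same read-out and stands within the usual scatter of both other compounds, so the three numbers cannot be ranked. Within the data shown here, compound 2 differs from compound 1 and from compound 3 in more than one place, and no measured pair isolates a single change.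

Compound 4 (`CCCCOc1cc(NC(=O)NNc2cc(-c3ccc(F)cc3)c3cnn(C)c3n2)cc(Cl)n1`) departs from compound 2 in one place, with butoxy in place of diethylamino on an aromatic carbon. That carbon belongs to a six-membered aromatic ring with 1 nitrogen and lies next to the ring nitrogen, meta to a chloro group.

Among the measured compounds shown here, no measured precedent exists for this exchange. For the measured compounds named here, the only guide is that compound 1 at 40800 nM and compound 3 at 50100 nM remain within the scatter of compound 2 at 37000 nM despite their differing structures. In this assay the expected change is a 1.1-fold lower number from compound 2 to compound 4 (0.02 log units; within the scatter) and is estimated to stay within the scatter, with neither direction favoured. The expected value for compound 4 is 35000 nM with an estimated range of 14000 nM to 80000 nM pending measurement.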

Compound 4, half-maximal effective concentration: 29300 nM
Estimate against measurement, compound 4: 1.2-fold (0.08 log units) above; low and high end bracket the measured number.
By their numbers in this assay, from the lowest: compounds 4, 2, 1 and 3 (each within the scatter of the next).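

Among these compounds, the exchange of diethylamino for butoxy, on an aromatic carbon next to the ring nitrogen and meta to a chloro group, provides the first single-place comparison: in this assay it gives a 1.3-fold lower number from compound 2 to compound 4 (0.10 log units; within the scatter) and so does not separate the two groups. The groups match in size and hydrogen-bond counts, each with four carbons, and differ in whether nitrogen or oxygen completes the group, so at this position and with this chain size, the swap from nitrogen to oxygen leaves no readable mark on the cytotoxicity read-out. Nothing measured alongside these numbers bears on why the two compounds read alike.

The compounds shown leave open whether this carbon can produce a step beyond the scatter at all, for example with a short methoxy group, a longer hexyloxy chain, a morpholine or a carboxylic acid in place of butoxy. Also open is whether the chloro group on the same ring matters to this result, as no compound shown replaces it while keeping butoxy or diethylamino.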